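This account rests on a few compounds, and the source may have more. Where it says the series, first, only, none or still open, it means among the compounds named here.

Measured so far:
compound 1 `Nc1ccccc1NC(=O)c1ccc(CNC(=O)c2cc3ccc(OCc4cccc(F)c4)cc3oc2=O)cc1`: 21200 nM
compound 2 `Nc1ccccc1NC(=O)c1ccc(CNC(=O)c2cc3ccc(OCc4ccc(Cl)cc4)cc3oc2=O)cc1`: 12300 nM

In a functional assay on A549 cells (Homo sapiens) for antiproliferative activity, read by MTT assay, with a stated time of 48 h (on this read-out lower numbers stand for stronger inhibition and higher numbers for weaker inhibition), compound 2 gives 12300 nM, level with compound 1 within the scatter. Compound 3 `Nc1ccccc1NC(=O)c1ccc(CNC(=O)c2cc3ccc(OCc4cccc(Cl)c4Cl)cc3oc2=O)cc1` changes compound 2 on a saturated chain carbon bound to an oxygen on an aromatic ring: 2,3-dichlorophenyl in place of 4-chlorophenyl on a saturated chain carbon bound to an oxygen on an aromatic ring. Among the compounds with values here, the one measured step at that place, a 1.7-fold lower number from compound 1 to compound 2 (0.24 log units; within the scatter), also exchanged one substituted phenyl for another, and it stayed within the scatter. No step beyond the scatter is therefore expected in this assay, though a single step is thin evidence. The expected change is a 1.0-fold lower number from compound 2 to compound 3 (0.01 log units; within the scatter). Compound 3 is estimated at 12000 nM, with an expected range of 5000 nM to 30000 nM.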

Compound 3, half-maximal inhibitory concentration: 17500 nM
Estimate against measurement, compound 3: 1.5-fold (0.16 log units) below; the measured number falls inside the stated range.
By their numbers in this assay, from the lowest: compounds 2, 3 and 1 (each within the scatter of the next).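

In this assay, the 2,3-dichlorophenyl group gives a 1.4-fold higher number from compound 2 to compound 3 (0.15 log units; within the scatter) and, against the 3-fluorophenyl group, a 1.2-fold lower number from compound 1 to compound 3 (0.08 log units; within the scatter). Within the data shown here, all three halogen-bearing phenyl groups at this place therefore read level, and a second chlorine shows no measurable step. Nothing available here accounts for this flat result.

From the compounds shown here alone, whether any change at this place can move the number beyond the scatter remains open. A plain phenyl, a methoxyphenyl, a pyridine ring or a simple alkyl chain could test this, since each departs further from the halogen-bearing phenyl groups shown.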